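This account rests on a few compounds, and the source may have more. Where it says the series, first, only, none or still open, it means among the compounds named here.

Values in a functional assay on SF-268 cells (Homo sapiens) for cytotoxicity, read by MTT assay, with a stated time of 3 days (a lower number here means a stronger inhibitor, a higher number a weaker inhibitor), so far:
compound 1 (`N#Cc1c(Cl)nc(SCc2nc3ccccc3[nH]2)nc1-c1ccccc1`) gives 3.2 nM
compound 2 (`N#Cc1c(Nc2ccccc2)nc(SCc2nc3ccccc3[nH]2)nc1-c1ccccc1`) gives 4.46 nM
compound 3 (`CNc1nc(SCc2nc3ccccc3[nH]2)nc(-c2ccccc2)c1C#N`) gives 3.2 nM

Compound 2 lies within the scatter of both other compounds, so the three values do not separate. Compound 4 (`CCNc1nc(SCc2nc3ccccc3[nH]2)nc(-c2ccccc2)c1C#N`) follows from compound 2 by ethyl in place of phenyl on a nitrogen on an aromatic ring. The closest measured change, methyl in place of phenyl at that same place, gave a 1.4-fold lower number from compound 2 to compound 3 (0.14 log units; within the scatter) as its result. Replacing chloro gave a 1.4-fold higher number from compound 1 to compound 2 (0.14 log units; within the scatter) with anilino and no change at the digits printed from compound 1 to compound 3 (within the scatter) with methylamino. On the strength of compound 3 at 3.2 nM in this series, no step beyond the scatter is expected in this assay for the new compound. The estimated step is a 1.3-fold lower number from compound 2 to compound 4 (0.11 log units; within the scatter) in this reading. For compound 4 the estimate is 3.5 nM with an expected range from 2 nM to 6.5 nM at this stage.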

Compound 4, half-maximal inhibitory concentration: 7.35 nM
Beside the measured number, compound 4's estimate is 2.1-fold (0.32 log units) below it, and the stated range ends below it.
By their numbers in this assay, from the lowest: compounds 1, 3, 2 and 4 (each within the scatter of the next, the first and the last beyond it).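

In this assay, going by these compounds alone, ethylamino in place of methylamino gives a 2.3-fold higher number from compound 3 to compound 4 (0.36 log units; beyond the scatter), the first step at this position beyond the scatter, though a modest one. Ethylamino in place of chloro gives a 2.3-fold higher number from compound 1 to compound 4 (0.36 log units; beyond the scatter), while ethylamino in place of anilino stays inside the scatter at a 1.6-fold higher number from compound 2 to compound 4 (0.22 log units; within the scatter). The position therefore shows a small but readable spread, which compound 2 does not separate from either end.

Still open, as far as these compounds go, are a propyl or longer chain on this nitrogen and the unsubstituted amino group, which would show whether the step continues with chain length. No measurement shown here bears on why the step arises.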